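Dropping the Bromine from Compound 3

The source may hold more compounds than are shown below. What is called first, only, known or untested is meant among the compounds shown, and "the series" means these compounds.

Compound 1 `O=C(Nc1ccc(Oc2ccnc3[nH]ccc23)c(F)c1)c1nn(-c2ccccc2)ccc1=O`: 38600 nM in a functional assay on PC-3 cells (Homo sapiens) for cytotoxicity, read by MTT assay, with a stated time of 72 h; a higher number here means a weaker inhibitor, a lower number a stronger inhibitor.
Compound 2 `Cn1ccc2c(Oc3ccc(NC(=O)c4nn(-c5ccc(Cl)cc5)ccc4=O)cc3F)ccnc21`: > 60000 nM, a limit of this assay.
Compound 3 `Cn1ccc2c(Oc3ccc(NC(=O)c4nn(-c5ccc(Br)cc5)ccc4=O)cc3F)ccnc21`: > 60000 nM, also a limit.

Compound 3 therefore stands at a limit of this assay, not at a number, and it shares that position with compound 2 (the limit of > 60000 nM in this assay, at which 2 of the 3 values shown sit). Compound 4 `Cn1ccc2c(Oc3ccc(NC(=O)c4nn(-c5ccccc5)ccc4=O)cc3F)ccnc21` differs from compound 3 only by hydrogen in place of bromo on an aromatic carbon. Among the compounds with values here, the one measured step, a step that the two limits leave unreadable from compound 2 to compound 3, lies between two limits and gives no readable size. The expectation for compound 4 rests instead on compound 1, which carries the same phenyl and gives 38600 nM. Compound 4 is expected to be a weak inhibitor, around 50000 nM, within a range of 20000 nM to 150000 nM. The step of an at least 1.2-fold lower number from compound 3 to compound 4 (0.07 log units; that floor lies within the scatter) thus expected cannot be sized, since compound 3 stands only at a limit.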

Compound 4, half-maximal inhibitory concentration: > 60000 nM
Compound 4 was reported as a limit (the forecaster's own chance of this, stated with the estimate: 50%); middle value at least 1.2-fold (0.07 log units) away from the limit.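

Compound 4 is reported only as a limit in this assay, so the phenyl without a halogen sits at the same limit as the chloro and bromo compounds: the limit of > 60000 nM in this assay, at which 3 of the 4 values shown sit.

All steps among compound 2, compound 3 and compound 4 join two limits and cannot be read. The one readable comparison, methyl in place of hydrogen on an aromatic nitrogen, gives an at least 1.5-fold higher number from compound 1 to compound 4 (0.19 log units; that floor lies within the scatter), so a real loss from this methyl is neither shown nor excluded.

As far as these compounds go, it remains open whether an amine or a carboxylic acid in place of bromo on that ring would give a measurable number in this assay. From the compounds shown here alone, whether hydrogen, chloro and bromo differ at all also stays open.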